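This account rests on a few compounds, and the source may have more. Where it says the series, first, only, none or still open, it means among the compounds named here.

Compound 1 `CNC(=O)c1cc(Oc2ccc(NC(=O)c3cc(-c4ccc(C(F)(F)F)cc4)ncn3)cc2F)ccn1` is tested in a functional assay on PC-3 cells (Homo sapiens) for cytotoxicity, read by MTT assay, with a stated time of 72 h; a lower number here means a stronger inhibitor, a higher number a weaker inhibitor. In this assay compound 1 gives only a limit, > 100000 nM, so where it stands is known just from the limit of > 100000 nM in this assay, at which 1 of the 2 values shown sits, and not from a number. Compound 2 `CNC(=O)c1cc(Oc2ccc(NC(=O)c3nccc(-c4ccc(C)cc4)n3)cc2F)ccn1` gives 28400 nM in this assay. Compound 3 `CCc1ccc(-c2cc(C(=O)Nc3ccc(Oc4ccnc(C(=O)NC)c4)c(F)c3)ncn2)cc1` differs from compound 1 in one place: ethyl in place of trifluoromethyl on an aromatic carbon. Going by the values given here, no measured step covers this change, and the values of compound 1 and compound 2 do not fix how it acts. A small move toward stronger inhibition is the expected step of an at least 2.0-fold lower number from compound 1 to compound 3 (0.30 log units; that floor lies within the scatter), though it may stay within scatter. Compound 3 is estimated at 50000 nM, between 15000 nM and 200000 nM.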

Compound 3, half-maximal inhibitory concentration: 15600 nM
For compound 3 the middle estimate is 3.2-fold (0.51 log units) above the measured one, within the range that was stated.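

Ethyl in place of trifluoromethyl on this aromatic carbon, para to a large group, gives an at least 6.4-fold lower number from compound 1 to compound 3 (0.80 log units; beyond the scatter) in this assay, so this position can move the read-out beyond the scatter. Compound 1 gives only a limit, > 100000 nM. The step is therefore a floor and its full size stays unknown: the limit of > 100000 nM in this assay, at which 1 of the 3 values shown sits.

A single change at this position cannot show whether ethyl itself matters or whether removing trifluoromethyl is enough. As far as these compounds go, how a longer chain such as propyl, an amine or a carboxylic acid would read here remains open.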